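The source may hold more compounds than are shown below. What is called first, only, known or untested is meant among the compounds shown, and "the series" means these compounds.

Measured in an ADME assay on a cell-free system (plasma, Homo sapiens) for metabolic stability, read by LC-MS; on this read-out higher numbers stand for a longer-lived compound and lower numbers for a shorter-lived compound:
- Compound 1 `COCCOC(=O)c1ccc(F)c(C(=O)Nc2cccc(-c3cc(C(=O)Nc4ccncc4F)ccc3CN)c2)c1`: < 0.0834 h (a limit)
- Compound 2 `NCc1ccc(C(=O)Nc2ccncc2F)cc1-c1cccc(C(=O)OCC2CCCO2)c1`: < 0.0834 h (a limit)

In this series, compound 2 gives < 0.0834 h in this assay, which is a limit and not a number. It shares this position with compound 1, as the limit of < 0.0834 h in this assay, at which 2 of the 2 values shown sit, shows, so no order can be read between the two.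

Compound 3 `NCc1ccc(C(=O)Nc2ccncc2F)cc1-c1cccc(C(=O)Nc2cccc(C(=O)O)c2F)c1` carries (3-carboxy-2-fluorophenyl)amino in place of (oxolan-2-yl)methoxy on a carbonyl carbon. Among the measured compounds shown here, no measured pair shows what such a change does in this assay, so the size of the step remains a judgement. A rise well beyond the scatter is expected, resting on the structural change and on compound 2 with its limit < 0.0834 h. The expected change is an at least 59-fold higher number from compound 2 to compound 3 (1.77 log units; beyond the scatter). For compound 3 the estimated half-life is 5 h, with an expected range of 0.5 h to 24 h.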

Compound 3, half-life: > 2 h
Compound 3: only a limit was reported; the forecaster's own chance of this, stated with the estimate: 40%; the middle value lies beyond the limit too.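

Until this point both compounds shown sat at the same limit, so nothing could be said about this position on a carbonyl carbon. Among the compounds shown here, the first readable step in this assay comes from replacing (oxolan-2-yl)methoxy with (3-carboxy-2-fluorophenyl)amino: an at least 23-fold higher number from compound 2 to compound 3 (1.37 log units; beyond the scatter) and it lies beyond the scatter. Compound 3 alone stands at the other end of the range, and its reading is a limit and not a number: the limit of > 2 h in this assay, at which 1 of the 3 values shown sits.

From the compounds shown here alone, the true size of the step stays open: both of its ends are limits. The compounds shown also leave open how the step divides among the amino link, the carboxylic acid and the fluorine, which a plain phenylamino group or a methylamino group in the same place would help to separate.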